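This account rests on a few compounds, and the source may have more. Where it says the series, first, only, none or still open, it means among the compounds named here.

Working notes on a quinolinone series read in a functional assay on LoVo cells (Homo sapiens) for cytotoxicity, read by colorimetric assay and MTT assay; a lower number here means a stronger inhibitor, a higher number a weaker inhibitor. Compound 1, `COc1cccc2cc(-c3ccccc3)c(O)nc12`, gives 10000 nM in this assay. Compound 2, `COc1ccc2cc(-c3ccccc3)c(O)nc2c1`, carries its methoxy on a different aromatic carbon of the shared core; in this assay compound 2 gives 10000 nM, level with compound 1 at the digits shown, so the two values fall within the scatter of each other and neither position of the single methoxy separates them.

The next member is compound 3, `COc1cc(OC)c2cc(-c3ccccc3)c(O)nc2c1`, which is not yet measured. Relative to compound 2 the change is methoxy in place of hydrogen on an aromatic carbon. Going by the values given here, nothing measured so far points to a gain or loss from adding a second methoxy: compound 1 and compound 2 stand together at weak potency. The step from compound 2 to compound 3 is therefore expected to be none beyond the scatter, no change at the digits printed from compound 2 to compound 3 (within the scatter). Compound 3 is expected to give about 10000 nM, within a range of 4000 nM to 25000 nM.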

Compound 3, half-maximal inhibitory concentration: 10000 nM
For compound 3 middle estimate and measured number coincide at the digits printed; the measured number falls inside the stated range.
By their numbers in this assay, from the lowest: compounds 1, 2 and 3 (each within the scatter of the next).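

The step from methoxy to a second methoxy on the shared core reads no change at the digits printed from compound 2 to compound 3 (within the scatter) in this assay, so this aromatic carbon, ortho to a fused ring and meta to a methoxy group, takes the added group with no separation between the two compounds. Compounds 1 and 2 compared only the place of a single methoxy, whereas this pair adds a second one, and the added methoxy likewise leaves the read-out undivided. Nothing at hand gives a reason for this flat reading.

The compounds shown leave open whether any group on this aromatic carbon can move the read-out away from the level shared by all three. An amine or a carboxylic acid there, or a longer chain in place of the methoxy, would test that.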